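Working notes: amine tail variation on a shared core

The source may report more compounds than this note shows. Statements on the series, on what has been measured and on what is new or still open speak of the compounds shown alone.

compound 1 `c1ccc(CN(CCCCN(C[C@H]2Cc3ccccc3CN2)[C@H]2CCCc3cccnc32)Cc2ccccn2)nc1`: > 30000 nM
compound 2 `c1ccc2c(c1)CN[C@@H](CN(CCCCNCC1CCCCC1)[C@H]1CCCc3cccnc31)C2`: > 30000 nM
compound 3 `c1ccc2c(c1)CN[C@@H](CN(Cc1ccc(CNCc3ccncc3)cc1)[C@H]1CCCc3cccnc31)C2`: > 30000 nM

In a functional assay on cells for agonist activity at C-X-C chemokine receptor type 4 (Homo sapiens), read by fluorescence and calcium flux, with a stated time of 90 s (on this read-out lower numbers stand for an effect already at smaller amounts and higher numbers for an effect only at larger amounts of compound), none of the three compounds gives a number, only a limit of the assay. Compound 1 stops at the limit > 30000 nM. Compound 2 likewise stops at the limit > 30000 nM. Compound 3 also stops at the limit > 30000 nM. Compound 2 therefore stands nowhere distinct on the numbers shown: every value sits at the limit of > 30000 nM in this assay, at which 3 of the 3 values shown sit, so no step between measured compounds can be read, and no gap between compound 2 and the others is known.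

The unmeasured compound 4 `CC(C)(CCN(C[C@H]1Cc2ccccc2CN1)[C@H]1CCCc2cccnc21)CNCC1CCOCC1` derives from compound 2 by a group of 12 heavy atoms (10 carbon, 1 nitrogen, 1 oxygen; one six-membered non-aromatic ring with 1 hetero atom) in place of a group of 10 heavy atoms (9 carbon, 1 nitrogen; one six-membered non-aromatic ring of carbon only), on a saturated chain carbon, two bonds along the chain from an amine nitrogen. Within the data shown here, with all measured values at the limit, no step in this assay is known beyond the scatter, and the measured values give no direction for the change.

The step that the limit leaves unreadable from compound 2 to compound 4 is expected to be none beyond the scatter, since the values of compound 2 and of the other two compounds all remain at the limit. The expectation for compound 4 is that this assay again reports a limit rather than a number. Compound 4 is estimated at 40000 nM, with a range from 15000 nM to 100000 nM.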

Compound 4, half-maximal effective concentration: > 30000 nM
Compound 4 ended at the assay's limit; the forecaster's own chance of this, stated with the estimate: 80%; the middle value is on the limit's open side.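

In this assay compound 2 and compound 4 both give only a limit and not a number, so no step between them can be read: the limit of > 30000 nM in this assay, at which 4 of the 4 values shown sit.

The compounds shown leave open whether any amine tail on the shared core gives a number in this assay at all, and what the group exchanged between compound 2 and compound 4 changes.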